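The source may hold more compounds than are shown below. What is called first, only, known or untested is meant among the compounds shown, and "the series" means these compounds.

Working notes on the series. Two compounds have numbers in an assay on isolated protein for inhibition of aldehyde dehydrogenase 1A1 (Homo sapiens), read by spectrophotometry, tested at 10 uM; on this read-out higher numbers stand for more inhibition at the one concentration tested (going by the name of the read-out) and lower numbers for less inhibition. Compound 1 `Cc1cccc(Cn2c(CN3CCN(C(=O)c4cccnc4)CC3)nc3ccccc32)c1` gives 24.5%. Compound 2 `CC(C)CCn1c(OC2CCN(C(=O)c3ccco3)CC2)nc2ccccc21` gives 30.8%; the two values lie within the usual scatter of each other, so neither is set apart. Compound 3 `Cc1cccc(Cn2c(CN3CCN(C(=O)c4ccc(C#N)cc4)CC3)nc3ccccc32)c1` is not yet measured. It differs from compound 1 by 4-cyanophenyl in place of pyridin-3-yl on a carbonyl carbon. Within the data shown here, no step between measured compounds bears on this change, so the expectation rests on compound 1 alone, with a step of a number 2.5 percentage points higher from compound 1 to compound 3 (within the scatter) expected to stay within the scatter, in no settled direction. Compound 3 is thus expected to give 27%, with a range from 10% to 45%.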

Compound 3, a percentage reported as inhibition, at one concentration (the size of the read-out at that concentration, not a potency): 20.8%
Compound 3: middle estimate off by 6.2 percentage points, on the high side; the measured number falls inside the stated range.
By their numbers in this assay, from the lowest: compounds 3, 1 and 2 (each within the scatter of the next).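

On the carbonyl carbon, 4-cyanophenyl in place of pyridin-3-yl gives a number 3.7 percentage points lower from compound 1 to compound 3 (within the scatter) in this assay. This position therefore accepts a larger group with a ring of carbon only and a nitrile, and the number does not move beyond the scatter. No other measurement bears on this result.

Going by these compounds, whether any group at this place can move the number beyond the scatter remains open, for example a carboxylic acid or a morpholine in place of pyridin-3-yl. On these data alone, whether the same change would read alike on the core of compound 2 also remains open.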